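Extending an alkoxy chain on a shared amide core

This account rests on a few compounds, and the source may have more. Where it says the series, first, only, none or still open, it means among the compounds named here.

Measured compounds:
Compound 1, `COc1cc(C(=O)Nc2nn[nH]n2)nc(-c2ccc(C)cc2)c1`, gives 16% in a functional assay on the whole organism for inhibition, with Rattus norvegicus as the target, at a dose of 0.3 mg/kg by the oral route; on this read-out lower numbers stand for a weaker effect and higher numbers for a stronger effect at the one dose given.
Compound 2, `CCOc1cc(C(=O)Nc2nn[nH]n2)nc(-c2ccc(C)cc2)c1`, gives 26% in this assay.
Compound 3, `CCOc1cc(C(=O)Nc2nn[nH]n2)nc(-c2ccc(N)cc2)c1`, gives 19% in this assay.

From compound 1 to compound 2 the change is methyl in place of hydrogen on a saturated chain carbon bound to an oxygen on an aromatic ring, and it gave a number 10 percentage points higher from compound 1 to compound 2 (within the scatter). From compound 2 to compound 3 the step was a number 7 percentage points lower from compound 2 to compound 3 (within the scatter). The difference between the cores of compound 1 and compound 3 is not broken down here.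

Compound 4, `CCCOc1cc(C(=O)Nc2nn[nH]n2)nc(-c2ccc(N)cc2)c1`, is not yet measured. It differs from compound 3 by methyl in place of hydrogen on a saturated chain carbon, two bonds along the chain from an oxygen on an aromatic ring. This is the same kind of change as from compound 1 to compound 2, but the place differs: there the methyl enters on a saturated chain carbon bound to an oxygen on an aromatic ring, here two bonds along the chain from that oxygen.

Resting on compound 1 and compound 2, where the step was a number 10 percentage points higher from compound 1 to compound 2 (within the scatter), the step to compound 4 is expected to be a number 6 percentage points higher from compound 3 to compound 4 (within the scatter). Compound 4 is therefore estimated at 25%, between 10% and 40%.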

Compound 4, a percentage reported as inhibition, in the whole organism at one dose (the size of the read-out at that dose, not a potency): 7%
The estimate for compound 4 lay 18 percentage points above the measured number; measured number outside the range, below it.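

In this assay, adding one methyl to the end of the alkoxy chain gave a number 12 percentage points lower from compound 3 to compound 4 (beyond the scatter) and so did not repeat the earlier result on the other core: the same change on two cores in this assay, a number 10 percentage points higher (within the scatter) from compound 1 to compound 2 and a number 12 percentage points lower (beyond the scatter) from compound 3 to compound 4, 22 percentage points apart, beyond the scatter of two such steps.
A step read on one core therefore cannot simply be carried over to another in this series. This does not show the reason, as the two steps differ both in the core and in the place where the methyl enters, and each rests on a single pair of compounds.

Still open, going by these compounds, is whether ethoxy to propoxy would go the same way on the core of compound 2, which carries a methyl where compound 3 carries an amino group. On these data alone, a longer chain, such as butoxy, is also open on either core.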